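The source may hold more compounds than are shown below. What is called first, only, known or untested is meant among the compounds shown, and "the series" means these compounds.

In an ADME assay on microsomes from liver (Rattus norvegicus) for metabolic stability, read by LC-MS, with a stated time of 30 min, tested at 0.1 uM (on this read-out lower numbers stand for a less stable compound and higher numbers for a more stable compound), compound 2 (`COc1ccc(Nc2cc3[nH]c(-c4cccc(C(F)(F)F)c4)nc3cn2)nc1`) gives 32%, the lowest of the three measured numbers. Compound 3 (`Fc1ccc(-c2nc3cnc(Nc4ccccn4)cc3[nH]2)cc1F`) gives 48% and compound 1 (`FC(F)(F)Oc1ccc(-c2nc3cnc(Nc4ccccn4)cc3[nH]2)cc1`) gives 61%, both beyond the scatter from compound 2. Compound 4 (`Fc1ccc(Nc2cc3[nH]c(-c4cccc(C(F)(F)F)c4)nc3cn2)nc1`) differs from compound 2 in one place: fluoro in place of methoxy on an aromatic carbon, para to a large group. Going by the values given here, no measured pair isolates this change, as compounds 1 and 3 differ from compound 2 elsewhere too. Still, neither carries methoxy, and compound 3, the nearer one at 48%, suggests a rise. The expected rise, beyond the scatter, is a number 15 percentage points higher from compound 2 to compound 4 (beyond the scatter). The estimate for compound 4 is 47%, within a range of 30% to 64%.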

Compound 4, percent of the compound remaining: 42%
Compound 4: the middle estimate sits 5 percentage points above what was measured; measured number inside the range.
By their numbers in this assay, from the lowest: compounds 2, 4 and 3 (each within the scatter of the next, the first and the last beyond it); then compound 1.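

Going by these compounds alone, this is the first pair in which one place alone changes: going from 5-methoxypyridin-2-yl to 5-fluoropyridin-2-yl, with the rest of the structure kept, this assay gives a number 10 percentage points higher from compound 2 to compound 4 (within the scatter). At this position, para to a large group, fluoro in place of methoxy therefore cannot be told apart from the usual scatter of the read-out. Nothing available explains this result.

The compounds shown leave open how an amine, a nitrile or a chloro group would read at this place. They also leave open whether the same change would read alike on compound 1, which carries trifluoromethoxy.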